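Benzylamine series on the trimethoxyaniline core: toward compound 3

A few compounds are considered here, and "the series" means these few. Any claim that something is new, unique, unknown or untested is made for them only; others in the source may bear on it.

The series pairs a shared trimethoxyaniline core with a benzyl group on the amine nitrogen, and all compounds are read in a functional assay on HCT-116 cells (Homo sapiens) for inhibition, read by MTT assay, with a stated time of 48 h; on this read-out higher numbers stand for weaker inhibition and lower numbers for stronger inhibition. Compound 1 `COc1ccc(CNc2cc(OC)c(OC)c(OC)c2)cc1` gives 18400 nM in this assay. Within the data shown here, compound 2 `COc1cc(NCc2cccc(O)c2)cc(OC)c1OC` gives 67700 nM in this assay, the highest of the two numbers so far; compound 1 sits a good way lower, and that gap lies beyond the usual scatter of repeated measurements. Among the measured compounds shown here, no pair of measured compounds differs in only one place, so no single step between measured compounds can be read off directly.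

Compound 3 `COc1cc(NCc2ccccc2)cc(OC)c1OC` is the next compound to be measured in this assay. Relative to compound 2 it differs in one place: hydrogen in place of hydroxy on an aromatic carbon, on an aromatic carbon of a six-membered aromatic ring of carbon only, meta to a large group; cut one bond further out, 3-hydroxyphenyl becomes phenyl.

Nothing in the measured pair tells how this particular change behaves. For the measured compounds named here, the only hint is that compound 1, which lacks a hydroxy on the benzyl ring, gives 18400 nM, a lower number than compound 2. On that basis a modest drop is expected, with the step of a 2.3-fold lower number from compound 2 to compound 3 (0.35 log units; beyond the scatter) estimated as small to moderate, in the direction of stronger inhibition. Compound 3 is therefore expected at about 30000 nM in this assay, within a range of 10000 nM to 90000 nM.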

Compound 3, half-maximal inhibitory concentration: > 80000 nM
Compound 3: no number, only a limit; the forecaster's own chance of this, stated with the estimate: 10%; middle value at least 2.6-fold (0.42 log units) from the limit.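

In this assay compound 3 carries no number, only a limit of the assay: the limit of > 80000 nM in this assay, at which 1 of the 3 values shown sits.

Replacing the hydroxy of the 3-hydroxyphenyl group with hydrogen gives an at least 1.1-fold higher number from compound 2 to compound 3 (0.07 log units; that floor lies within the scatter), so this change does not bring the lower number that compound 1 had suggested, though with only a floor printed, its true size stays unfixed and no order between these two compounds can be claimed beyond the scatter. Hydrogen in place of the methoxy of compound 1 gives an at least 4.3-fold higher number from compound 1 to compound 3 (0.63 log units; beyond the scatter), the first single-place step in the series that is read beyond the scatter, and it shows that the methoxy-bearing compound keeps a measurable number in this assay where the unsubstituted phenyl compound reaches the limit.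

From the compounds shown here alone, the true value of compound 3 cannot be read from a limit, so the full size of both steps stays open. Also open, going by these compounds, is whether an ethoxy group, a chlorine or an amine on the same aromatic ring would hold, lower or lose the number of compound 1.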